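The source may hold more compounds than are shown below. What is called first, only, known or untested is meant among the compounds shown, and "the series" means these compounds.

Working notes on the series, read in a functional assay on MDA-MB-435 cells (Homo sapiens) for cytotoxicity, read by MTT assay, with a stated time of 72 h; a higher number here means a weaker inhibitor, a lower number a stronger inhibitor. Compound 1 `C[C@@H](Nc1c(C(=O)NCc2ccc(F)cc2)nc(Br)c2cccnc12)c1ccccc1` gives > 20000 nM, a limit and not a number. Compound 3 `O=C(NCc1ccc(F)cc1)c1nc(Br)c2cccnc2c1NCCO` gives > 20000 nM, likewise a limit. Among the measured compounds shown here, compound 2 `NCCCNc1c(C(=O)NCc2ccc(F)cc2)nc(Br)c2cccnc12` gives 5000 nM, the only true number so far. On these data alone, compound 3 thus stands on (the limit of > 20000 nM in this assay, at which 2 of the 3 values shown sit), and its real position is unknown.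

Next is compound 4 `O=C(NCc1ccc(F)cc1)c1nc(Br)c2cccnc2c1N1CCNCC1`, with piperazin-1-yl in place of (2-hydroxyethyl)amino on an aromatic carbon, para to a bromo group.

For the measured compounds named here, two measured steps bear on this. The first is an at least 4.0-fold lower number from compound 1 to compound 2 (0.60 log units; beyond the scatter), and the second is an at least 4.0-fold higher number from compound 2 to compound 3 (0.60 log units; beyond the scatter), where hydroxy replaces aminomethyl. Both are modest at minimum, and both favour compound 2 with its 3-aminopropyl group. The third, a step that the two limits leave unreadable from compound 1 to compound 3, cannot be read. Compound 4 also loses the hydroxy and gains a nitrogen, so compound 2 is the nearest guide, though its chain is open and the piperazin-1-yl group is a ring.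

The expected change is an at least 2.8-fold lower number from compound 3 to compound 4 (0.45 log units; beyond the scatter), a modest move towards stronger inhibition. For compound 4 the estimated value is 7000 nM, with an expected range of 2500 nM to 20000 nM.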

Compound 4, half-maximal inhibitory concentration: 8000 nM
The estimate for compound 4 lay 1.1-fold (0.06 log units) below the measured number; measured number inside the range.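

In this assay, a ring at this aromatic carbon, para to the bromo group, keeps a true number: piperazin-1-yl gives an at least 2.5-fold lower number from compound 3 to compound 4 (0.39 log units; beyond the scatter) and an at least 2.5-fold lower number from compound 1 to compound 4 (0.39 log units; beyond the scatter). The ring and the open chain of compound 2 cannot be told apart, as a 1.6-fold higher number from compound 2 to compound 4 (0.20 log units; within the scatter) shows. Compound 2 and compound 4 each carry an amine nitrogen at the far part of this group, and the two compounds without one give only a limit: the limit of > 20000 nM in this assay, at which 2 of the 4 values shown sit.

On these data alone, it remains open whether that amine nitrogen is needed or any six-membered ring would serve here. A morpholin-4-yl or piperidin-1-yl group in this place would separate the two, and a 4-methylpiperazin-1-yl group would show whether the amine hydrogen matters.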